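The source may hold more compounds than are shown below. What is called first, only, known or untested is meant among the compounds shown, and "the series" means these compounds.

The measured compounds in this study:

- compound 1 `CO[C@@H]1[C@@H](OC)[C@H](c2ccccc2)O[C@@H]2CO[C@@H](c3ccc(C)cc3)O[C@@H]12`: "not determined" (no result reported)
- compound 2 `CO[C@@H]1[C@@H](OC)[C@H](c2ccccc2)O[C@@H]2CO[C@@H](c3ccc([N+](=O)[O-])cc3)O[C@@H]12`: "not determined" (no result reported)
- compound 3 `CO[C@@H]1[C@@H](OC)[C@H](c2ccccc2)O[C@@H]2CO[C@@H](c3ccc(Cl)cc3)O[C@@H]12`: > 50 ug/mL

Three compounds share one core and differ only in the substituent on the outer aromatic ring. For compound 1 and compound 2 no result in a functional assay on HEL cells (Homo sapiens) for cytotoxicity (a higher number here means that more compound is tolerated, a lower number that less compound is tolerated), has been reported, so nothing can be said of their tolerability. Among the compounds with values here, compound 3 is the only one with a reading in this assay, and that reading is a limit of the assay rather than a number: compound 3 reaches the limit of > 50 ug/mL in this assay, at which 1 of the 3 values shown sits, without a half-maximal cytotoxic concentration being found within the tested range.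

The next compound, compound 4 `CO[C@@H]1[C@@H](OC)[C@H](c2ccccc2)O[C@@H]2CO[C@@H](c3ccc(C(F)(F)F)cc3)O[C@@H]12`, differs from compound 3 in one place: trifluoromethyl in place of chloro on an aromatic carbon. Within the data shown here, no step between two measured compounds is available here, so no measured size of change can guide the estimate. The account expects the step in this assay to be none beyond the usual scatter, that is a number no higher from compound 3 to compound 4 (the limit leaves the size open), since compound 3 already sits at the limit.

Compound 4 is therefore estimated to give about 50 ug/mL in this assay, within a range from 25 ug/mL to 100 ug/mL.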

Compound 4, half-maximal cytotoxic concentration: > 50 ug/mL
Compound 4: no number, only a limit; the forecaster's own chance of this, stated with the estimate: 75%; the middle value lies on the limit itself.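

Compound 3 and compound 4 both end at a limit rather than a number, so no step can be read from compound 3 to compound 4 in this assay: the limit of > 50 ug/mL in this assay, at which 2 of the 4 values shown sit.

The compounds shown leave open where either half-maximal cytotoxic concentration lies, and whether trifluoromethyl and chloro differ in tolerability at all.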